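A few compounds are considered here, and "the series" means these few. Any claim that something is new, unique, unknown or untested is made for them only; others in the source may bear on it.

Three compounds that share one core were tested in an in vitro assay on SH-EP1 cells for displacement of a labelled ligand from Neuronal acetylcholine receptor; alpha4/beta2 (Homo sapiens); a higher number here means a weaker inhibitor, a lower number a stronger inhibitor. Compound 1 `COc1cc(C2=CC3CC(C2)CN(C)C3)cnc1Cl` gives 4.4 nM. Compound 2 `Clc1ccc(C2=CC3CNCC(C2)C3)cn1` gives 0.4 nM. Compound 3 `Clc1ccc(Oc2cncc(C3=CC4CNCC(C3)C4)c2)cc1` gives 1.9 nM, the second highest of the three numbers; it sits above compound 2 and below compound 1, and both of those gaps lie beyond the scatter.

Compound 4 `Fc1ccc(Oc2cncc(C3=CC4CNCC(C3)C4)c2)cc1` differs from compound 3 in one place: fluoro in place of chloro on an aromatic carbon. For the measured compounds named here, no pair of measured compounds differs in this way alone, so no measured step guides the expectation. Compound 4 is expected to land close to compound 3, with the step of a 1.3-fold higher number from compound 3 to compound 4 (0.12 log units; within the scatter) within the scatter or only slightly toward a weaker value. Compound 4 is therefore estimated at 2.5 nM, with a range from 1 nM to 6 nM.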

Compound 4, inhibition constant: 0.6 nM
The estimate for compound 4 lay 4.2-fold (0.62 log units) above the measured number; the whole stated range lies above it.
By their numbers in this assay, from the lowest: compounds 2 and 4 (each within the scatter of the next); then compound 3; then compound 1.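

In this assay the change from 4-chlorophenyl to 4-fluorophenyl gives a 3.2-fold lower number from compound 3 to compound 4 (0.50 log units; beyond the scatter) and so shows that this position responds to the exchange of one halogen for another. For the compounds shown here, the earlier compounds offered no pair that differed here alone, so this is the first reading of the position. No measurement shown accounts for the step. The compounds shown leave open how a methoxy group, a nitrile or a plain hydrogen at this place would compare with fluoro. They also leave open whether the same exchange would give a similar step on another compound sharing the core.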